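Switching a naphthyl for a nitrophenyl on an isoxazole ether

The source may report more compounds than this note shows. Statements on the series, on what has been measured and on what is new or still open speak of the compounds shown alone.

Compound 1 `CCOC(=O)C1=Cc2ccccc2OC1(OCc1cn(CC(=O)Nc2ccc(C)cc2)nn1)C(F)(F)F` gives 67400 nM in a functional assay on HeLa cells (Homo sapiens) for inhibition, read by MTT assay, with a stated time of 24 h; a higher number here means a weaker inhibitor, a lower number a stronger inhibitor.
Compound 2 `CCOC(=O)C1=Cc2ccccc2OC1(OCc1cc(-c2ccc3ccccc3c2)no1)C(F)(F)F` gives only a limit, > 150000 nM, in this assay.
Compound 3 `O=C(O)C1=Cc2ccccc2OC1(OCc1cc(-c2ccc3ccccc3c2)no1)C(F)(F)F` likewise gives only a limit, > 150000 nM, in this assay.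

On the numbers shown, compound 2 stands at a limit and nowhere else; the step that the two limits leave unreadable from compound 2 to compound 3 cannot be read because of the limit of > 150000 nM in this assay, at which 2 of the 3 values shown sit. Compound 4 `CCOC(=O)C1=Cc2ccccc2OC1(OCc1cc(-c2ccc([N+](=O)[O-])cc2)no1)C(F)(F)F` differs from compound 2 by 4-nitrophenyl in place of naphthalen-2-yl on an aromatic carbon. No measured step touches this exchange: the only step shown is unreadable, and compound 1 carries a different five-membered ring altogether. The size and direction of the change in this assay is therefore open, though a weak result like that of compound 2 remains the plainest guess. Compound 4 is expected to give about 120000 nM, between 40000 nM and 400000 nM, a step of an at least 1.2-fold lower number from compound 2 to compound 4 (0.09 log units; that floor lies within the scatter) that is itself only an estimate.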

Compound 4, half-maximal inhibitory concentration: > 150000 nM
Compound 4: no number, only a limit; the forecaster's own chance of this, stated with the estimate: 55%; middle value at least 1.2-fold (0.09 log units) away from the limit.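

Among these compounds, compound 4, like compound 2, gives only a limit, so no step from compound 2 to compound 4 can be read: the limit of > 150000 nM in this assay, at which 3 of the 4 values shown sit. The compounds shown leave open how far 4-nitrophenyl in place of naphthalen-2-yl shifts the number in this assay and in which direction.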